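The source may hold more compounds than are shown below. What is called first, only, known or untested is meant among the compounds shown, and "the series" means these compounds.

Compound 2 `COc1ccccc1/C=c1\sc2nc(-c3cn(C4CC4)c4cc(N5CCN(C)CC5)c(F)cc4c3=O)nn2c1=O` is one of two close relatives tested in a functional assay on CAPAN-1 cells (Homo sapiens) for cytotoxicity; on this read-out higher numbers stand for weaker inhibition and lower numbers for stronger inhibition. In this assay compound 2 gives only a limit of > 10000 nM, not a number. Compound 1 `CN1CCN(c2cc3c(cc2F)c(=O)c(-c2nc4s/c(=C\c5cccc(C#N)c5)c(=O)n4n2)cn3C2CC2)CC1` likewise gives only a limit of > 10000 nM in this assay. The step that the two limits leave unreadable from compound 1 to compound 2 therefore cannot be read, because the limit of > 10000 nM in this assay, at which 2 of the 2 values shown sit, holds both values. Compound 3 `COc1ccc(/C=c2\sc3nc(-c4cn(C5CC5)c5cc(N6CCN(C)CC6)c(F)cc5c4=O)nn3c2=O)cc1` is the next relative, differing from compound 2 only in one place: 4-methoxyphenyl in place of 2-methoxyphenyl on a double-bonded chain carbon bound to an aromatic carbon. For the measured compounds named here, no measured step sheds light on this change, since the one comparison available stays at the limit on both sides. The expectation is that compound 3 remains as weak as its two relatives, so an estimated step that the limit leaves unreadable from compound 2 to compound 3 is assumed, within the scatter. Compound 3 is expected to show about 15000 nM in this assay, somewhere between 5000 nM and 50000 nM, most likely reported again as a limit.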

Compound 3, half-maximal inhibitory concentration: > 10000 nM
Compound 3: no number, only a limit (the forecaster's own chance of this, stated with the estimate: 80%); the middle value is on the limit's open side.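

In this assay compound 3 also gives only a limit, so its steps from compound 1 and compound 2 cannot be read: the limit of > 10000 nM in this assay, at which 3 of the 3 values shown sit.

The compounds shown leave open whether 3-cyanophenyl, 2-methoxyphenyl or 4-methoxyphenyl changes cytotoxicity at all, since none has a true number.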